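Methoxy removal on the cinnamoyl ring of hydroxychalcones

This account rests on a few compounds, and the source may have more. Where it says the series, first, only, none or still open, it means among the compounds named here.

Of the compounds shown here, three have been measured in a physicochemical assay for lipophilicity; a higher number here means a more lipophilic compound, a lower number a more polar compound. Compound 1 `COc1ccc(C(=O)/C=C/c2ccc(OC)c(OC)c2)c(O)c1` gives 3.53. Compound 2 `COc1ccc(C(=O)/C=C/c2cc(OC)c(OC)c(OC)c2)c(O)c1` gives 3.49. Compound 3 `COc1ccc(O)c(C(=O)/C=C/c2ccc(OC)c(OC)c2)c1` gives 3.52, which stands second highest of the three, closest to compound 1 and a little further from compound 2, both gaps within the scatter.

One single-point change is documented among the measured compounds: hydrogen in place of methoxy on an aromatic carbon This gave a number 0.04 log units higher from compound 2 to compound 1 (within the scatter), so the loss of one methoxy left the partition coefficient essentially where it was. How the core of compound 3 differs from the core of compound 2 is not broken down here.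

Compound 4 `COc1ccc(/C=C/C(=O)c2cc(OC)ccc2O)cc1` is still to be measured in this assay. It arises from compound 3 by the same kind of change: hydrogen in place of methoxy on an aromatic carbon The surroundings are not identical, however: in the step from compound 2 to compound 1 the position was also meta to a methoxy group (2 heavy atoms), whereas in compound 3 it is not.

Given that the one documented instance of this change moved the value by a number 0.04 log units higher from compound 2 to compound 1 (within the scatter), the step from compound 3 to compound 4 is expected to be of similar size, a number 0.04 log units higher from compound 3 to compound 4 (within the scatter), because a number 0.04 log units higher from compound 2 to compound 1 (within the scatter) showed no shift beyond the scatter. Compound 4 is therefore estimated at 3.56, with a likely range from 3.3 to 3.82.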

Compound 4, partition coefficient: 3.87
For compound 4 the middle estimate is 0.31 log units below the measured one; the measured number lies above the stated range.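

In this assay the replacement of methoxy by hydrogen on an aromatic carbon now has two readings: a number 0.04 log units higher from compound 2 to compound 1 (within the scatter) and a number 0.35 log units higher from compound 3 to compound 4 (beyond the scatter). The first lies within the scatter and the second beyond it, so in these two instances the change does not carry from one core to the other at a fixed size, and a step read on one core is a weak guide to the same step on the other. The two instances differ both in the core and in the surroundings of the place, which from compound 3 to compound 4 is ortho to a methoxy group and meta to a large group, so the data do not separate these two factors, and nothing available bears on why the step beyond the scatter arises.

On these data alone, whether the same replacement on a third core would fall nearer the first reading or the second remains open. Also open, as far as these compounds go, is how a group other than hydrogen, such as an amine, a carboxylic acid or a longer alkoxy chain, would read in this assay at this same place on the core of compound 4.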